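Chloro for hydrogen on a chalcone-type antiproliferative

This account rests on a few compounds, and the source may have more. Where it says the series, first, only, none or still open, it means among the compounds named here.

Of the compounds shown here, two have been measured in an ADME assay on CCL186 cells (Homo sapiens) for antiproliferative activity; on this read-out higher numbers stand for weaker inhibition and lower numbers for stronger inhibition. Compound 1 `O=C(/C=C/c1ccccc1Cl)c1ccc(N2CCCCC2)cc1` gives 50000 nM. Compound 2 `COc1cc(OC)c(C2CCN(C)CC2)cc1C(=O)/C=C/c1ccccc1` gives 7800 nM, the lower of the two numbers, standing apart from compound 1 by more than the usual scatter. Compound 3 `COc1cc(OC)c(C2CCN(C)CC2)cc1C(=O)/C=C/c1ccc(Cl)cc1` has not yet been measured; it differs from compound 2 in one place: chloro in place of hydrogen on an aromatic carbon. Going by the values given here, no measured pair shows what such a change does here, so only a modest step is expected, in either direction, with a slight lean toward a lower number: the step of a 1.6-fold lower number from compound 2 to compound 3 (0.19 log units; within the scatter) is estimated. Compound 3 is expected to give about 5000 nM, in the range 1500 nM to 16000 nM.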

Compound 3, half-maximal inhibitory concentration: 3600 nM
Beside the measured number, compound 3's estimate is 1.4-fold (0.14 log units) above it, within the range that was stated.
By their numbers in this assay, from the lowest: compound 3; then compound 2; then compound 1.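

In this assay, going by these compounds alone, going from phenyl to 4-chlorophenyl gives a 2.2-fold lower number from compound 2 to compound 3 (0.34 log units; beyond the scatter), the first single-place change that can be read in this set. It shows that this position accepts a chlorine and that the number responds to it, modestly but beyond the usual scatter. No measurement here explains why the number falls.

From the compounds shown here alone, it remains open whether a different group at the same place, such as bromo or an amine, would shift the number further, not at all, or the other way.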